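Expected Inhibition After Swapping Trichlorophenyl for Dichlorophenyl

This account rests on a few compounds, and the source may have more. Where it says the series, first, only, none or still open, it means among the compounds named here.

Compound 2 `NC1=NC2(CCOCC2)N(OCCCOc2cc(Cl)c(Cl)cc2Cl)C(N)=N1` is the starting point. In an assay on isolated protein for inhibition of Dihydrofolate reductase (Homo sapiens), read by spectrophotometry, using NADPH, with stated times of 5 s and 6 min, tested at 5 uM (a higher number here means a stronger effect of the compound at the concentration tested, a lower number a weaker effect), compound 2 gives > 90%, which is a limit of the assay rather than a number. Compound 1 `NC1=NC2(CCOCC2)N(OCCCOc2ccc(F)cc2)C(N)=N1` likewise gives > 90%, again a limit. Going by the values given here, the only step between measured compounds, a step that the two limits leave unreadable from compound 1 to compound 2, cannot be sized because both of its ends sit at the limit of > 90% in this assay, at which 2 of the 3 values shown sit. Compound 3 `NC1=NC2(CCSCC2)N(OCCCOc2cccc(Cl)c2Cl)C(N)=N1` gives 83.8%. It carries the same 2,3-dichlorophenyl that compound 4 will carry, though on a core differing from that of compound 2. Compound 4 `NC1=NC2(CCOCC2)N(OCCCOc2cccc(Cl)c2Cl)C(N)=N1` differs from compound 2 by 2,3-dichlorophenyl in place of 2,4,5-trichlorophenyl on an oxygen on a saturated carbon. No readable step bears on this change, so the expected step of a number at least 4 percentage points lower from compound 2 to compound 4 (that floor lies within the scatter) rests on compound 3 alone. Compound 4 is expected to give about 86%, within 72% to 93%.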

Compound 4, a percentage reported as inhibition, at one concentration (the size of the read-out at that concentration, not a potency): 81.7%
The estimate for compound 4 lay 4.3 percentage points above the measured number; low and high end bracket the measured number.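

On the shared core, compound 4 gives the first reading below the limit, so this position now has a measurable point. Putting 2,3-dichlorophenyl in place of 2,4,5-trichlorophenyl gives a number at least 8.3 percentage points lower from compound 2 to compound 4 (that floor lies within the scatter), and putting it in place of 4-fluorophenyl gives a number at least 8.3 percentage points lower from compound 1 to compound 4 (that floor lies within the scatter). These steps have only floors, and the step between compound 1 and compound 2 remains unreadable, because both compounds stand at a limit rather than a number: the limit of > 90% in this assay, at which 2 of the 4 values shown sit.

Going by these compounds, the true size of each step remains open. So does whether an amine or a carboxylic acid on the phenyl ring, or a longer chain, would keep the inhibition.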